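Methyl on the distal ring of a biphenyl sulfonamide

The source may hold more compounds than are shown below. What is called first, only, known or untested is meant among the compounds shown, and "the series" means these compounds.

Working notes on a small set of meta-hydroxymethyl anilides tested in a functional assay on J774 cells (Mus musculus) for cytotoxicity, read by resazurin assay, with a stated time of 72 h; a higher number here means a weaker inhibitor, a lower number a stronger inhibitor. Going by the values given here, compound 1 `O=S(=O)(Nc1cccc(CO)c1)c1ccc(-c2ccccc2)cc1` is the only member of the set with a measured number: in this assay compound 1 gives 2200 nM. Among the compounds with values here, compound 2 `O=C(Nc1cccc(CO)c1)c1ccc(-c2ccc(F)cc2F)cc1` returns no number in this assay but only a limit, > 15000 nM; it sits at the limit of > 15000 nM in this assay, at which 1 of the 2 values shown sits, so nothing beyond that limit can be said of it, and no step between compound 1 and compound 2 is given.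

Compound 3 `Cc1ccc(-c2ccc(S(=O)(=O)Nc3cccc(CO)c3)cc2)cc1` is not yet measured. It differs from compound 1 in one place: methyl in place of hydrogen on an aromatic carbon. Within the data shown here, no measured pair in the set shows what such a change does in this assay, so the expectation rests on the size of the change alone, which adds a single carbon and no donors or acceptors. The step from compound 1 to compound 3 is expected to be small and to fall within the usual scatter of repeated measurements, with no direction claimed: a 1.2-fold lower number from compound 1 to compound 3 (0.06 log units; within the scatter).

For compound 3 the estimate in this assay is therefore 1900 nM, with a range from 700 nM to 5500 nM.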

Compound 3, half-maximal inhibitory concentration in the J774 assay: 1200 nM
Compound 3: middle estimate off by 1.6-fold (0.20 log units), on the high side, and the stated range covers the measured number.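

Going by these compounds alone, in the J774 assay compound 1 gives 2200 nM and compound 3 gives 1200 nM; the change from phenyl to 4-methylphenyl, with the methyl on an aromatic carbon para to a large group, gives the first step that can be read at this position: a 1.8-fold lower number from compound 1 to compound 3 (0.26 log units; within the scatter). Within the data shown here, this single pair therefore gives no sign that methyl in place of hydrogen here moves the number beyond what repeated measurements would give, which the earlier compounds could not show, since they offered no step at all. In a physicochemical assay for solubility, read by HPLC, in simulated intestinal fluid, measured as thermodynamic solubility, with a stated time of 24 h (a lower number here means a less soluble compound, a higher number a more soluble compound), compound 1 gives 11 ug/mL and compound 3 gives 21 ug/mL, and the same change reads a 1.9-fold higher number from compound 1 to compound 3 (0.28 log units; within the scatter), so on this pair neither read-out separates the two compounds, and nothing measured here gives a cause for either step.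

From the compounds shown here alone, one pair with one small group sets no trend, and it remains open whether a longer chain such as ethyl, an amine or a carboxylic acid at the same position would give a step beyond the scatter in either read-out. Also open, going by these compounds, is whether the same methyl would give a comparable step on a core other than that of compound 1.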